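A few compounds are considered here, and "the series" means these few. Any claim that something is new, unique, unknown or untested is made for them only; others in the source may bear on it.

Measured compounds in a functional assay on MDA-MB-231 cells (Homo sapiens) for antiproliferative activity, read by MTT assay, with a stated time of 72 h; on this read-out higher numbers stand for weaker inhibition and lower numbers for stronger inhibition:
compound 1, `CCN(CC)CCn1cnnc1-c1cc(Oc2ccc(NC(=O)Nc3ccc(Cl)c(C(F)(F)F)c3)cc2F)ccn1`: 1540 nM
compound 2, `CCN(CC)CCn1cnnc1-c1cc(Oc2ccc(NC(=O)Nc3cccc(C(F)(F)F)c3)cc2F)ccn1`: 720 nM
compound 3, `CN(C)CCCn1cnnc1-c1cc(Oc2ccc(NC(=O)Nc3ccc(Cl)c(C(F)(F)F)c3)cc2F)ccn1`: 7880 nM

Compounds 1 and 2 share a core and differ only by hydrogen in place of chloro on an aromatic carbon; in this assay this gives a 2.1-fold lower number from compound 1 to compound 2 (0.33 log units; beyond the scatter). Compounds 1 and 3 differ in the core by (dimethylamino)methyl in place of diethylamino on a saturated chain carbon, two bonds along the chain from an aromatic nitrogen, which gives a 5.1-fold higher number from compound 1 to compound 3 (0.71 log units; beyond the scatter), so compound 3 has the highest number of the three measured compounds.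

Compound 4, `CN(C)CCCn1cnnc1-c1cc(Oc2ccc(NC(=O)Nc3cccc(C(F)(F)F)c3)cc2F)ccn1`, is not yet measured in this assay. It differs from compound 3 by hydrogen in place of chloro on an aromatic carbon. Within the data shown here, this is the same change as from compound 1 to compound 2, at the same place on the ring, and no other pair shows it. Among the measured compounds shown here, the step from compound 1 to compound 2, a 2.1-fold lower number from compound 1 to compound 2 (0.33 log units; beyond the scatter), is the only measured guide, and it is modest, so a step of similar size is expected from compound 3 to compound 4: a 2.1-fold lower number from compound 3 to compound 4 (0.33 log units; beyond the scatter). Because compound 3 gives 7880 nM, compound 4 is expected to give about 3700 nM. For the measured compounds named here, the expected range for compound 4 is 1600 nM to 9000 nM, which is wide because only one earlier instance of the change, a 2.1-fold lower number from compound 1 to compound 2 (0.33 log units; beyond the scatter), supports the estimate.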

Compound 4, half-maximal inhibitory concentration: 13300 nM
For compound 4 the middle estimate is 3.6-fold (0.56 log units) below the measured one; measured number outside the range, above it.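

In this assay, hydrogen in place of chloro gives a 1.7-fold higher number from compound 3 to compound 4 (0.23 log units; within the scatter), which does not repeat the step seen with the diethylamino chain: the same change on two cores in this assay, a 2.1-fold lower number (0.33 log units; beyond the scatter) from compound 1 to compound 2 and a 1.7-fold higher number (0.23 log units; within the scatter) from compound 3 to compound 4, 3.6-fold (0.56 log units) apart, beyond the scatter of two such steps The change from diethylamino to (dimethylamino)methyl gives an 18-fold higher number from compound 2 to compound 4 (1.27 log units; beyond the scatter), and its size also depends on the core: the same change on two cores in this assay, a 5.1-fold higher number (0.71 log units; beyond the scatter) from compound 1 to compound 3 and an 18-fold higher number (1.27 log units; beyond the scatter) from compound 2 to compound 4, 3.6-fold (0.56 log units) apart, beyond the scatter of two such steps Neither change therefore carries over at a fixed size, although the chain change gives a higher number on both cores, but the two gaps come from the same four compounds and count as one observation, which shows neither a cause nor how either step would behave on a further core.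

The compounds shown leave open whether the dependence holds for other amines on the chain, such as a pyrrolidine or a morpholine in place of diethylamino. They also leave open how a fluoro or a methyl group in place of chloro would behave with each chain.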